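The source may hold more compounds than are shown below. What is called first, only, known or untested is meant among the compounds shown, and "the series" means these compounds.

Working notes on the furan-free series? No — on the shared core of compound 1 `C=CC1=C(C(=O)Nc2ccccc2OC)C(c2ccc(F)cc2)OC1` and its amide variants. In a functional assay on SW480 cells (Homo sapiens) for cytotoxicity, read by MTT assay, with a stated time of 24 h (a higher number here means a weaker inhibitor, a lower number a stronger inhibitor), compound 1 gives > 100000 nM, which is a limit of the assay and not a number. Compound 2 `C=CC1=C(C(=O)Nc2ccccc2OC)C(c2ccc(OC)cc2)OC1` in this assay gives > 100000 nM, again a limit. Among the compounds with values here, the one step measured within the set, a step that the two limits leave unreadable from compound 1 to compound 2, therefore carries no readable size. Within the data shown here, compound 3 `C=CC1=C(C(=O)NCCCCC)C(c2ccc(Cl)c(Cl)c2)OC1` is the only member with a number, giving 27500 nM in this assay. Compound 1 thus stands only at the limit of > 100000 nM in this assay, at which 2 of the 3 values shown sit, with no measured position in the range of numbers.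

Compound 4 `C=CC1=C(C(=O)NCC(C)C)C(c2ccc(F)cc2)OC1` is the unmeasured member. It differs from compound 1 by isobutyl in place of 2-methoxyphenyl on an amide-type nitrogen. Among the measured compounds shown here, no measured step bears on this exchange at the amide nitrogen: the single step in hand concerns the aromatic ring, and it is unreadable. For the measured compounds named here, compound 3, which also carries a chain on the amide nitrogen, is the only member to give a number in this assay, but it differs from compound 1 in two places at once, so no step can be drawn from it.

The expectation for compound 4 is therefore weak. Compound 4 is estimated at 60000 nM, within 20000 nM to 200000 nM; the implied step an at least 1.6-fold lower number from compound 1 to compound 4 (0.22 log units; that floor lies within the scatter) is likewise an estimate only.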

Compound 4, half-maximal inhibitory concentration: > 100000 nM
Compound 4 ended at the assay's limit; the forecaster's own chance of this, stated with the estimate: 50%; middle value at least 1.6-fold (0.22 log units) from the limit.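

In this assay compound 4 gives > 100000 nM as a limit of the assay and not a number. Within the data shown here, compound 1 also sits at a limit, so no step from compound 1 to compound 4 can be read. The compounds shown leave open which of the two places where compound 3 differs from compound 1 goes with its number.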